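Ring nitrogen group: from compound 3 to compound 4

The compounds below may be only part of what the source reports. "The series", "measured", "known", "first", "only" and "open" are said of these compounds alone.

In a physicochemical assay for solubility, read by turbidimetry, measured as kinetic solubility, at pH 7.4 (a lower number here means a less soluble compound, a higher number a more soluble compound), compound 3 (`O=C(NCCCCc1ccccc1)c1cccc(C2SCC(=O)N2c2ccccn2)c1`) gives 20000 nM, level with compound 2 (`O=C(NCCCCc1ccccc1)c1cccc(C2SCC(=O)N2c2cccc(-c3c[nH]nn3)c2)c1`) at 20000 nM. Compound 1 (`COc1ccc(F)cc1N1C(=O)CSC1c1cccc(C(=O)NCCCCc2ccccc2)c1`) gives 10000 nM, within the scatter of both. The next structure, compound 4 (`C#Cc1cccc(N2C(=O)CSC2c2cccc(C(=O)NCCCCc3ccccc3)c2)c1`), has 3-ethynylphenyl in place of pyridin-2-yl on an amide-type nitrogen in a ring.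

Three measured steps changed the group at this same nitrogen: a 2.0-fold higher number from compound 1 to compound 3 (0.30 log units; within the scatter), a 2.0-fold higher number from compound 1 to compound 2 (0.30 log units; within the scatter) and no change at the digits printed from compound 2 to compound 3 (within the scatter). All three lie within the scatter, so no change beyond the scatter is expected in this assay, and the direction is only weakly indicated. The expected step is a 1.4-fold lower number from compound 3 to compound 4 (0.15 log units; within the scatter). For compound 4, the estimated value is 14000 nM, with an expected range of 6000 nM to 28000 nM.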

Compound 4, solubility: 10000 nM
Estimate against measurement, compound 4: 1.4-fold (0.15 log units) above; measured number inside the range.
By their numbers in this assay, from the lowest: compounds 1, 4, 2 and 3 (each within the scatter of the next).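

In this assay, the all-carbon 3-ethynylphenyl at the amide-type nitrogen in a ring stays within the scatter of pyridin-2-yl (a 2.0-fold lower number from compound 3 to compound 4 (0.30 log units; within the scatter)) and of 5-fluoro-2-methoxyphenyl (no change at the digits printed from compound 1 to compound 4 (within the scatter)). Ethynyl in place of 1H-1,2,3-triazol-4-yl on the aromatic carbon also stays within the scatter (a 2.0-fold lower number from compound 2 to compound 4 (0.30 log units; within the scatter)), so the four groups at this nitrogen, with or without hetero atoms, are not separated in this assay. Nothing measured here explains these numbers.

Still open, going by these compounds, is whether an amine or a carboxylic acid on the ring at this nitrogen would give a step beyond the scatter.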